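The source may report more compounds than this note shows. Statements on the series, on what has been measured and on what is new or still open speak of the compounds shown alone.

Compound 1, `CNc1nc(-c2ccccc2)nc2c1nnn2Cc1ccccc1Cl`, gives 191000000 nM in an assay on isolated protein for binding affinity to adenosine receptor A1 (Bos taurus); on this read-out lower numbers stand for stronger inhibition and higher numbers for weaker inhibition.
Compound 2, `CCNc1nc(-c2ccccc2)nc2c1nnn2Cc1ccccc1Cl`, gives 463000000 nM in this assay.
Compound 3, `CCCNc1nc(-c2ccccc2)nc2c1nnn2Cc1ccccc1`, gives 37000000 nM in this assay.

Compounds 1 and 2 share one core; compound 3 differs from compound 1 in the core, and the difference between the two cores is not broken down here. Within the first core, compound 2 differs from compound 1 by methyl in place of hydrogen on a saturated chain carbon bound to a nitrogen on an aromatic ring, and that change made a 2.4-fold higher number from compound 1 to compound 2 (0.38 log units; beyond the scatter). Compound 3 stands lowest of the three measured numbers, well apart from compound 1 and further still from compound 2.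

Compound 4, `CCCCNc1nc(-c2ccccc2)nc2c1nnn2Cc1ccccc1`, is not yet measured. It differs from compound 3 by methyl in place of hydrogen on a saturated chain carbon, three bonds along the chain from a nitrogen on an aromatic ring. Within the data shown here, this is the same kind of change as the one from compound 1 to compound 2, but the place is not identical: in the earlier pair it sits on a saturated chain carbon bound to a nitrogen on an aromatic ring, whereas here it sits three bonds along the chain from that nitrogen. Resting on the one comparable step, the one seen from compound 1 to compound 2, compound 4 is expected to move by a 1.8-fold higher number from compound 3 to compound 4 (0.24 log units; within the scatter) in this assay. Compound 4 is therefore estimated at 65000000 nM, between 20000000 nM and 200000000 nM.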

Compound 4, inhibition constant: 11000000 nM
Compound 4: the middle estimate sits 5.9-fold (0.77 log units) above what was measured; the whole stated range lies above it.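

In this assay, methyl in place of hydrogen on a saturated chain carbon, three bonds along the chain from a nitrogen on an aromatic ring, made a 3.4-fold lower number from compound 3 to compound 4 (0.53 log units; beyond the scatter). This step therefore did not repeat the earlier one on the other core, and the two run in opposite directions: the same change on two cores in this assay, a 2.4-fold higher number (0.38 log units; beyond the scatter) from compound 1 to compound 2 and a 3.4-fold lower number (0.53 log units; beyond the scatter) from compound 3 to compound 4, 8.2-fold (0.91 log units) apart, beyond the scatter of two such steps

This does not show that the core alone separates the two results, since the place of the change also differs: on the carbon bound to that nitrogen in one pair, three bonds along the chain from it in the other. Among these compounds, with only one step on each core, the pairs give no rule for carrying this change across the series, only a warning against assuming that it transfers.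

The compounds shown leave open whether a pentyl chain on the core of compound 4 would continue the fall in the number seen with the butyl chain. They also leave open how a propyl or butyl chain would behave on the core of compound 1, which would set the core apart from the place of the change.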